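The source may report more compounds than this note shows. Statements on the series, on what has been measured and on what is new or still open speak of the compounds shown alone.

Measured so far:
- Compound 1, `Cc1[nH]c2ccc(F)cc2c1C1=CCNCC1`: 30 nM
- Compound 2, `CSc1ccc2[nH]c(C)c(C3=CCNCC3)c2c1`: 20 nM

Both compounds were tested in an assay on HEK293 cells for displacement of a labelled ligand from 5-hydroxytryptamine receptor 6 (Homo sapiens), read by scintillation counting, with a stated time of 1 h; a higher number here means a weaker inhibitor, a lower number a stronger inhibitor. Within the data shown here, compound 2 holds the lowest of the two numbers, but its only neighbour is compound 1, and the step of a 1.5-fold lower number from compound 1 to compound 2 (0.18 log units; within the scatter) lies within the scatter, so the two values cannot be told apart.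

Compound 3, `Cc1[nH]c2ccc(-c3ccsc3)cc2c1C1=CCNCC1`, has not yet been measured. It differs from compound 2 in one place: thiophen-3-yl in place of methylsulfanyl on an aromatic carbon.

Among the measured compounds shown here, only one measured step is available, and it concerns a different change at the same position: exchanging fluoro for methylsulfanyl, which gave a 1.5-fold lower number from compound 1 to compound 2 (0.18 log units; within the scatter). Nothing measured shows what a thiophen-3-yl at this place does. For the measured compounds named here, the one step seen at this position stayed within the scatter, so no step beyond the scatter is expected in this assay for compound 3, with wide uncertainty.

Compound 3 is therefore estimated at 25 nM, within 6 nM to 100 nM, an expected step of a 1.3-fold higher number from compound 2 to compound 3 (0.10 log units; within the scatter).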

Compound 3, half-maximal inhibitory concentration: 700 nM
For compound 3 the middle estimate is 28-fold (1.45 log units) below the measured one; the measured number lies above the stated range.
By their numbers in this assay, from the lowest: compounds 2 and 1 (each within the scatter of the next); then compound 3.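

Two steps now show how much this change costs: a 35-fold higher number from compound 2 to compound 3 (1.54 log units; beyond the scatter) when thiophen-3-yl replaces methylsulfanyl, and a 23-fold higher number from compound 1 to compound 3 (1.37 log units; beyond the scatter) when it replaces fluoro. Fluoro and methylsulfanyl could not be told apart in this assay, so the position looked open to change, but that holds only for those two groups, as a thiophen-3-yl on this aromatic carbon gives a much weaker inhibitor. No measurement here gives a reason for this loss.

The compounds shown leave open whether the loss follows the aromatic ring itself or the larger count of heavy atoms in the group. An open chain such as butyl, a small ring such as cyclopropyl, or a phenyl ring at the same carbon could help separate these two readings.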